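This account rests on a few compounds, and the source may have more. Where it says the series, first, only, none or still open, it means among the compounds named here.

Measured compounds:
Compound 1, `CC(c1ccc(-c2ccccc2)c(F)c1)c1nnc2n1N=C(c1ccccc1)CS2`: in a functional assay on HCT-116 cells (Homo sapiens) for inhibition, read by sulforhodamine B assay, with a stated time of 72 h (on this read-out lower numbers stand for stronger inhibition and higher numbers for weaker inhibition), compound 1 gives 9700 nM.
Compound 2, `CC(c1ccc(-c2ccccc2)c(F)c1)c1nnc2n1N=C(c1ccc(Br)cc1)CS2`: in this assay compound 2 gives 7100 nM.

Among the measured compounds shown here, compound 2 holds the lower of the two numbers so far, but its only neighbour is compound 1, and the step of a 1.4-fold lower number from compound 1 to compound 2 (0.14 log units; within the scatter) lies within the scatter, so the two values are not separated from each other. Compound 3, `CC(c1ccc(-c2ccccc2)c(F)c1)c1nnc2n1N=C(c1ccc(F)cc1)CS2`, has not yet been measured in this assay. It differs from compound 2 by fluoro in place of bromo on an aromatic carbon. For the measured compounds named here, the one measured step that bears on this place is a 1.4-fold lower number from compound 1 to compound 2 (0.14 log units; within the scatter), which shows that introducing bromo on that aromatic carbon left the number essentially where it stood. With one halogen traded for another at the same carbon, no step beyond the scatter is expected in this assay in either direction. Compound 3 is therefore estimated at 8500 nM, within 4000 nM to 18000 nM, corresponding to an expected step of a 1.2-fold higher number from compound 2 to compound 3 (0.08 log units; within the scatter).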

Compound 3, half-maximal inhibitory concentration: 10500 nM
Compound 3: middle estimate off by 1.2-fold (0.09 log units), on the low side, and the stated range covers the measured number.
By their numbers in this assay, from the lowest: compounds 2, 1 and 3 (each within the scatter of the next).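

In this assay, the exchange of 4-bromophenyl for 4-fluorophenyl (a 1.5-fold higher number from compound 2 to compound 3 (0.17 log units; within the scatter)) and the comparison of fluoro with hydrogen on the same aromatic carbon (a 1.1-fold higher number from compound 1 to compound 3 (0.03 log units; within the scatter)) both lie within the scatter. Hydrogen, fluoro and bromo on this carbon, para to a large group, are therefore not separated from one another, and this now holds for two different halogens rather than for bromo alone. Nothing available explains this result.

Going by these compounds, whether a group of another kind on this carbon, such as an amine, a carboxylic acid or a longer chain, would give a step beyond the scatter remains open. On these data alone, the three compounds vary only this one carbon, so the contribution of the rest of the shared core is also open.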